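Chloro for Methyl: Expected Cytotoxicity of Compound 4

The source may report more compounds than this note shows. Statements on the series, on what has been measured and on what is new or still open speak of the compounds shown alone.

Measured compounds:
Compound 1, `COc1cc2ncnc(NNC(=S)NC(=O)c3ccccc3C)c2cc1OC`: 21500 nM
Compound 2, `Cc1ccc(C(=O)NC(=S)NNc2ncnc3ccccc23)cc1`: 11200 nM
Compound 3, `COc1cc2ncnc(NNC(=S)NC(=O)c3ccccc3Cl)c2cc1OC`: 10000 nM

All three were tested in a functional assay on GLC82 cells (Homo sapiens) for cytotoxicity, read by MTT assay, with a stated time of 72 h; on this read-out lower numbers stand for stronger inhibition and higher numbers for weaker inhibition. Compound 2 stands second highest of the three with 11200 nM; its gaps to compound 3 and to compound 1 both lie within the scatter, so no order among them can be read. Compound 4, `O=C(NC(=S)NNc1ncnc2ccccc12)c1ccc(Cl)cc1`, is not yet measured and differs from compound 2 in one place: chloro in place of methyl on an aromatic carbon. One measured step matches this change, a 2.2-fold lower number from compound 1 to compound 3 (0.33 log units; beyond the scatter), a modest shift toward a lower number. On that basis the step from compound 2 is expected to read a 2.0-fold lower number from compound 2 to compound 4 (0.30 log units; within the scatter). Compound 4 is therefore estimated at 5600 nM, with a range from 2500 nM to 12000 nM.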

Compound 4, half-maximal inhibitory concentration: 6680 nM
Compound 4: middle estimate off by 1.2-fold (0.08 log units), on the low side; low and high end bracket the measured number.
By their numbers in this assay, from the lowest: compounds 4, 3, 2 and 1 (each within the scatter of the next, the first and the last beyond it).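

In this assay, chloro in place of methyl on the 4-methylphenyl group of compound 2 gives a 1.7-fold lower number from compound 2 to compound 4 (0.22 log units; within the scatter), so this step alone does not separate the two groups. The change now stands on a second core, at a place para to a large group, and the two steps agree in size: the same change on two cores in this assay, a 2.2-fold lower number (0.33 log units; beyond the scatter) from compound 1 to compound 3 and a 1.7-fold lower number (0.22 log units; within the scatter) from compound 2 to compound 4, 1.3-fold (0.11 log units) apart, within the scatter of two such steps

The compounds shown leave open how an amine or a carboxylic acid at this place would read against chloro and methyl. They also leave open whether the agreement between the two steps extends beyond these two cores.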